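Fluoro in place of trifluoromethyl on the aromatic ring

This account rests on a few compounds, and the source may have more. Where it says the series, first, only, none or still open, it means among the compounds named here.

Going by the values given here, in a functional assay on A549 cells (Homo sapiens) for antiproliferative activity, read by MTT assay (a higher number here means a weaker inhibitor, a lower number a stronger inhibitor), compound 1 `COc1cc2c(Oc3ccc(NC(=O)Nc4ccc(OC(F)(F)F)cc4)cc3)ccnc2cc1OCCCCCCC(=O)NO` gives 3130 nM and compound 2 `COc1cc2c(Oc3ccc(NC(=O)Nc4ccccc4C(F)(F)F)cc3)ccnc2cc1OCCCCCCC(=O)NO` gives 5280 nM within the scatter of that first value, so the two cannot be ranked and compound 2 has no separate standing so far. Compound 3 `COc1cc2c(Oc3ccc(NC(=O)Nc4ccccc4F)cc3)ccnc2cc1OCCCCCCC(=O)NO` carries fluoro in place of trifluoromethyl on an aromatic carbon, ortho to a large group, with fluoro in place of trifluoromethyl on an aromatic carbon as the counted difference from compound 2. Among the compounds with values here, the one measured step that bears on this is a 1.7-fold higher number from compound 1 to compound 2 (0.23 log units; within the scatter) and it lies within the scatter, although it exchanged a different pair of groups, 2-(trifluoromethyl)phenyl in place of 4-(trifluoromethoxy)phenyl. Within the data shown here, no measured compound carries 2-fluorophenyl, so the size of the present change cannot be read directly. A step beyond the scatter in this assay is not expected, and no direction is firm. Compound 3 is estimated at 4000 nM with an expected range from 1800 nM to 9000 nM on this reading. The estimated step is a 1.3-fold lower number from compound 2 to compound 3 (0.12 log units; within the scatter) and it stays within the scatter.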

Compound 3, half-maximal inhibitory concentration: 870 nM
The estimate for compound 3 lay 4.6-fold (0.66 log units) above the measured number, outside the stated range (below it).
By their numbers in this assay, from the lowest: compound 3; then compounds 1 and 2 (each within the scatter of the next).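

In this assay, this aromatic carbon, ortho to a large group, proves sensitive to the group it carries: fluoro in place of trifluoromethyl gives a 6.1-fold lower number from compound 2 to compound 3 (0.78 log units; beyond the scatter), a step beyond the scatter. Compound 3 also separates from the 4-(trifluoromethoxy)phenyl compound, with 2-fluorophenyl in its place giving a 3.6-fold lower number from compound 1 to compound 3 (0.56 log units; beyond the scatter), so a change in the aryl group on the amide-type nitrogen can move this read-out, which a 1.7-fold higher number from compound 1 to compound 2 (0.23 log units; within the scatter) did not show. Nothing available on these compounds accounts for the size of either step.

Going by these compounds, whether the lower number follows from fluoro itself or simply from the removal of trifluoromethyl stays open, and chloro, methyl or plain hydrogen on the same aromatic carbon would separate those two readings. On these data alone, it is equally open whether fluoro on another aromatic carbon of that ring would give a similar number in this assay.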